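Notes on the amine nitrogen change from compound 2 to 4

A few compounds are considered here, and "the series" means these few. Any claim that something is new, unique, unknown or untested is made for them only; others in the source may bear on it.

The series comprises compound 1 `CCCn1c(=O)[nH]c2nc(-c3ccc(S(=O)(=O)N(C)C)cc3)[nH]c2c1=O`, compound 2 `CCCn1c(=O)[nH]c2nc(-c3ccc(S(=O)(=O)N4CCN(Cc5cccc(Br)c5)CC4)cc3)[nH]c2c1=O`, compound 3 `CCCn1c(=O)[nH]c2nc(-c3ccc(S(=O)(=O)N4CCN(c5ccccc5)C(C)C4)cc3)[nH]c2c1=O` and the not yet measured compound 4 `CCCn1c(=O)[nH]c2nc(-c3ccc(S(=O)(=O)N4CCN(C(C)c5ccccc5)CC4)cc3)[nH]c2c1=O`. In an assay on CHO cells for displacement of a labelled ligand from adenosine receptor A2b (Homo sapiens), read by scintillation counting, with a stated time of 75 min, in the presence of a further agent that is not named here (on this read-out higher numbers stand for weaker inhibition and lower numbers for stronger inhibition), compound 1 gives 18.6 nM. In this assay compound 3 gives 7.15 nM. In this assay compound 2 gives 0.148 nM, the lowest of the three numbers; compound 3 stands nearest and compound 1 furthest, both gaps beyond the scatter, so compound 2 is the strongest inhibitor among the measured three.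

Compound 4 differs from compound 2 in one place: 1-phenylethyl in place of 3-bromobenzyl on an amine nitrogen in a ring. For the measured compounds named here, no pair of measured compounds differs by a step of this kind, so its size in this assay cannot be read off the data. Going by the values given here, the measured numbers show only that compound 2, which carries the 3-bromobenzyl group on the amine nitrogen in the ring, sits far from compound 3 and compound 1, which lack that group. With the bromine gone and the benzyl carbon carrying a methyl, a moderate move toward a higher number, near the edge of the scatter, is expected rather than a return to the level of compound 3. Compound 4 is expected to give 0.5 nM, within 0.1 nM to 2.5 nM. The expected step in this assay is a 3.4-fold higher number from compound 2 to compound 4 (0.53 log units; beyond the scatter).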

Compound 4, inhibition constant: 8.34 nM
Estimate against measurement, compound 4: 17-fold (1.22 log units) below, outside the stated range (above it).
By their numbers in this assay, from the lowest: compound 2; then compounds 3 and 4 (each within the scatter of the next); then compound 1.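

On an amine nitrogen in a ring, 1-phenylethyl in place of 3-bromobenzyl gives a 56-fold higher number from compound 2 to compound 4 (1.75 log units; beyond the scatter) in this assay, so this position responds strongly to a change between two groups with the same count of heavy atoms, one six-membered aromatic ring of carbon only, no hydrogen-bond donors or acceptors and no net charge. The earlier compounds shown here differ from one another in more than one place and could not isolate the contribution of this group; this step shows that the high potency of compound 2 depends on the exact form of its substituent, not merely on having an aromatic ring on this nitrogen. Nothing measured here accounts for the size of the step.

The step combines loss of the bromine with a methyl on the benzyl carbon, and the compounds shown do not separate the two; an unsubstituted benzyl group and a 1-(3-bromophenyl)ethyl group would each isolate one part. Also open, as far as these compounds go, is how a longer chain, such as 2-phenylethyl, would fare on the same nitrogen.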